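Flipping the Single Stereocentre of Compound 1

The source may report more compounds than this note shows. Statements on the series, on what has been measured and on what is new or still open speak of the compounds shown alone.

Compound 1 `CCCC[C@H]1NC(=O)c2ccccc21` is a small molecule carrying a butyl chain on a ring and a single stereocentre. In a functional assay on cells (Platelet, Oryctolagus cuniculus) for inhibition, read by turbidimetry, with a stated time of 5 min (on this read-out lower numbers stand for stronger inhibition and higher numbers for weaker inhibition), compound 1 gives 680000 nM, a high number that means only weak inhibition of clotting. Two much larger compounds were measured beside it. Compound 2 `CCCC[C@H](OC(=O)CN1CCCC1)c1ccccc1C(=O)O[C@H]1CO[C@H]2[C@@H]1OC[C@H]2OC(=O)c1ccccc1[C@H](CCCC)OC(=O)CN1CCCC1` gives 640000 nM in this assay, and compound 3 `CCCC[C@@H](OC(=O)CN1CCCC1)c1ccccc1C(=O)O[C@H]1CO[C@H]2[C@@H]1OC[C@H]2OC(=O)c1ccccc1[C@@H](CCCC)OC(=O)CN1CCCC1` gives 910000 nM. Among these three numbers compound 1 stands second highest, closest to compound 2 and furthest from compound 3, with both gaps falling within the scatter of the assay. The step of a 1.4-fold higher number from compound 2 to compound 3 (0.15 log units; within the scatter) is likewise within the scatter, and it rests on (the fact that compounds 2 and 3 differ only in the configuration as drawn).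

Compound 4 `CCCC[C@@H]1NC(=O)c2ccccc21` is the mirror image of compound 1 at its one stereocentre: the two compounds have the same atoms and bonds and differ only in configuration as drawn: 1 of 1 stereo elements differ; a stereocentre at a saturated ring carbon is drawn R in compound 1 and S in compound 4. Among the compounds with values here, the only measured step that bears on a change of configuration alone is the one from compound 2 to compound 3, and that step stayed within the scatter. The expected step from compound 1 to compound 4 is therefore a 1.0-fold higher number from compound 1 to compound 4 (0.01 log units; within the scatter), with no movement beyond the scatter. Compound 4 is estimated at 700000 nM, within a range from 300000 nM to 1600000 nM.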

Compound 4, half-maximal inhibitory concentration: 420000 nM
For compound 4 the middle estimate is 1.7-fold (0.22 log units) above the measured one; the range from low to high includes it.
By their numbers in this assay, from the lowest: compounds 4, 2, 1 and 3 (each within the scatter of the next, the first and the last beyond it).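

Inverting the single stereocentre, at a saturated ring carbon rather than at the saturated chain carbons that were inverted in the larger compounds, gives a 1.6-fold lower number from compound 1 to compound 4 (0.21 log units; within the scatter) in this assay. Within the data shown here, this is the first reading of a configuration change at this ring position in the small compound, and it shows that the two mirror forms cannot be told apart in this read-out, with both remaining high numbers that stand for weak inhibition. The step can be read as the effect of configuration alone, since no atom enters or leaves and the earlier step, a 1.4-fold higher number from compound 2 to compound 3 (0.15 log units; within the scatter), involved two stereocentres rather than one: the fact that compounds 1 and 4 differ only in the configuration as drawn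

Going by these compounds, whether this stereocentre would count for more with a different group on it remains open, for instance a longer chain than butyl, or a chain ending in an amine or a carboxylic acid. The compounds shown also do not tell whether the same lack of a clear difference between the two configurations would hold in a compound with a much lower number in this assay.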